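A few compounds are considered here, and "the series" means these few. Any claim that something is new, unique, unknown or untested is made for them only; others in the source may bear on it.

Measured in a functional assay on A549 cells (Homo sapiens) for antiproliferative activity, with a stated time of 5 days; a lower number here means a stronger inhibitor, a higher number a weaker inhibitor:
Compound 1 `COc1ccc(-n2nc(-c3ccc4ccccc4c3)nc2N2C(=O)COC23C=CC(=O)C=C3)cc1`: 260 nM
Compound 2 `CC1CN(c2nc(-c3ccc4ccccc4c3)nn2-c2ccccc2)C2(C=CC(=O)C=C2)O1`: 320 nM
Compound 3 `Cc1ccccc1-n1nc(-c2cccc3ccccc23)nc1N1C(=O)COC12C=CC(=O)C=C2`: 130 nM

Compound 1 stands within the usual scatter of both compound 2 and compound 3, so it cannot be separated from either. Compound 4 `O=C1C=CC2(C=C1)OCC(=O)N2c1nc(-c2ccc3ccccc3c2)nn1-c1ccc2ccccc2c1` has not been measured yet. It carries naphthalen-2-yl in place of 4-methoxyphenyl on an aromatic nitrogen. Going by the values given here, no two measured compounds differ in one place only, so no direct step guides this change. Compound 2 at 320 nM and compound 3 at 130 nM carry other groups on that nitrogen, yet neither leaves the scatter around compound 1. No step beyond the scatter is expected, in either direction. The estimated change is a 1.1-fold lower number from compound 1 to compound 4 (0.05 log units; within the scatter). Compound 4 is expected at 230 nM, within an estimated range of 80 nM to 650 nM.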

Compound 4, half-maximal inhibitory concentration: 250 nM
Compound 4: the middle estimate sits 1.1-fold (0.04 log units) below what was measured; the range from low to high includes it.
By their numbers in this assay, from the lowest: compounds 3, 4, 1 and 2 (each within the scatter of the next, the first and the last beyond it).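

In this assay, going by these compounds alone, naphthalen-2-yl in place of 4-methoxyphenyl on the aromatic nitrogen gives a 1.0-fold lower number from compound 1 to compound 4 (0.02 log units; within the scatter) as the first step that can be read at this position. The entering group has two six-membered aromatic rings of carbon only and lacks the oxygen of 4-methoxyphenyl, yet the step stays within the scatter. Nothing at hand explains this outcome. Still open, on these data alone, is whether an amine or a carboxylic acid on this nitrogen's aromatic ring, or a longer chain on the nitrogen itself, would move the number beyond the scatter.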